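Chloro in place of trifluoromethyl on the piperidinyl ring

The source may report more compounds than this note shows. Statements on the series, on what has been measured and on what is new or still open speak of the compounds shown alone.

Among the compounds with values here, in a physicochemical assay for solubility, in simulated intestinal fluid (on this read-out lower numbers stand for lower solubility and higher numbers for higher solubility), compound 2 `COc1ccccc1C(=O)NC(=O)Nc1ccc(N2CCCCC2)c(C(F)(F)F)c1` gives 4.1 ug/mL, the lowest of the two numbers measured so far; compound 1 `COc1ccccc1C(=O)NC(=O)Nc1ccc(-c2ccccc2)c(C(F)(F)F)c1` gives 23 ug/mL, and the step of a 5.6-fold lower number from compound 1 to compound 2 (0.75 log units; beyond the scatter) lies beyond the scatter. Compound 3 `COc1ccccc1C(=O)NC(=O)Nc1ccc(N2CCCCC2)c(Cl)c1` differs from compound 2 by chloro in place of trifluoromethyl on an aromatic carbon. Within the data shown here, the only measured step alters a different group, so no measured step bears directly on this change; nothing in the data points to a move beyond the scatter. The expected step of a 1.2-fold higher number from compound 2 to compound 3 (0.09 log units; within the scatter) therefore stays within the scatter. Compound 3 is estimated at 5 ug/mL, with a range from 2 ug/mL to 12 ug/mL.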

Compound 3, solubility: 8.5 ug/mL
Compound 3: middle estimate off by 1.7-fold (0.23 log units), on the low side, within the range that was stated.
By their numbers in this assay, from the lowest: compound 2; then compound 3; then compound 1.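

In this assay, chloro in place of trifluoromethyl on this aromatic carbon, ortho to a piperidin-1-yl group, gives a 2.1-fold higher number from compound 2 to compound 3 (0.32 log units; beyond the scatter), so this position also moves the read-out. Within the data shown here, the earlier step changed only the group at the piperidin-1-yl place, so this is the first reading at this carbon. No measurement at hand accounts for the size or direction of this step.

On these data alone, whether the step carries over with phenyl in place of piperidin-1-yl remains open. So does the reading in this assay for a nitrile or a primary amine on this carbon.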